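Lipophilicity notes: oxazolidinone series, chain substituent variation

This account rests on a few compounds, and the source may have more. Where it says the series, first, only, none or still open, it means among the compounds named here.

Measured so far:
compound 1, `CCN1CCN(C[C@H]2CN(c3ccc(-n4cc(-c5ccccn5)cn4)c(F)c3)C(=O)O2)CC1`: 2.19
compound 2, `COC(=O)CC1CCN(C[C@H]2CN(c3ccc(-n4cc(-c5ccccn5)cn4)c(F)c3)C(=O)O2)CC1`: 1.78
compound 3, `COC[C@H]1CN(c2ccc(-n3cc(-c4ccccn4)cn3)c(F)c2)C(=O)O1`: 2.18

In a physicochemical assay for lipophilicity, read by HPLC, measured as octanol-water partition (a lower number here means a more polar compound, a higher number a more lipophilic compound), compound 3 stands second highest of the three numbers, next to compound 1 and furthest from compound 2. The step of a number 0.01 log units lower from compound 1 to compound 3 (within the scatter) lies within the scatter, whereas a number 0.40 log units higher from compound 2 to compound 3 (beyond the scatter) is beyond it. Going by the values given here, the one change that separates these compounds sits on the saturated chain carbon bound to a saturated ring carbon, and that is also where compound 4, `COC(=O)NC[C@H]1CN(c2ccc(-n3cc(-c4ccccn4)cn3)c(F)c2)C(=O)O1`, departs from compound 3: (methoxycarbonyl)amino in place of methoxy on a saturated chain carbon bound to a saturated ring carbon.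

Among the compounds with values here, none of the measured steps replaces a methoxy with a group that carries a hydrogen-bond donor, so none bears on this change directly. The steps of a number 0.41 log units lower from compound 1 to compound 2 (beyond the scatter) and a number 0.40 log units higher from compound 2 to compound 3 (beyond the scatter) show only that swapping the chain substituent can move this assay by a modest amount. Given the added donor and acceptor counted in the change, a modest downward step, a number 0.48 log units lower from compound 3 to compound 4 (beyond the scatter), is expected. Compound 4 is estimated at 1.7, within 1.3 to 2.1.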

Compound 4, partition coefficient: 2.03
Estimate against measurement, compound 4: 0.33 log units below; low and high end bracket the measured number.
By their numbers in this assay, from the lowest: compounds 2, 4, 3 and 1 (each within the scatter of the next, the first and the last beyond it).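

In this assay, exchanging methoxy for (methoxycarbonyl)amino on a saturated chain carbon bound to a saturated ring carbon brings in a hydrogen-bond donor, yet a number 0.15 log units lower from compound 3 to compound 4 (within the scatter) stays within the scatter, so at this position that donor-bearing group is not separated from methoxy. Compound 4 is also not separated from either amine-containing substituent, since a number 0.25 log units higher from compound 2 to compound 4 (within the scatter) and a number 0.16 log units lower from compound 1 to compound 4 (within the scatter) both lie within the scatter, even though compounds 1 and 2 lie beyond the scatter of each other. No measurement shown here accounts for this result.

Open, going by these compounds, is whether a carboxylic acid or a primary amine on this chain carbon would move the number beyond the scatter from compound 3. Also open, on these data alone, is whether a longer chain on the carbamate oxygen, in place of its methyl, would do so.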